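Methyl for methoxy on a weakly cytotoxic fused core

A few compounds are considered here, and "the series" means these few. Any claim that something is new, unique, unknown or untested is made for them only; others in the source may bear on it.

- compound 1 `c1ccc2[nH]c(-n3cccn3)cc2c1`: > 100000 nM (a limit)
- compound 2 `COc1ccc2[nH]c(-c3ccc[nH]3)cc2c1`: 55000 nM
- compound 3 `COc1ccc2[nH]c3c4cn[nH]c4c4c(c3c2c1)C(=O)NC4=O`: > 100000 nM (a limit)

All three compounds were tested in a functional assay on A549 cells (Homo sapiens) for cytotoxicity, read by MTT assay, with a stated time of 72 h (on this read-out lower numbers stand for stronger inhibition and higher numbers for weaker inhibition), and are shown with their results there. Compound 3 gives > 100000 nM, which is a limit of the assay and not a number. Within the data shown here, it thus stands at the limit of > 100000 nM in this assay, at which 2 of the 3 values shown sit, and compound 2 is the only one with a number.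

The next compound is compound 4 `Cc1ccc2[nH]c3c4cn[nH]c4c4c(c3c2c1)C(=O)NC4=O`, which carries methyl in place of methoxy on an aromatic carbon of a six-membered aromatic ring of carbon only, part of a fused or bridged system of five rings: methyl in place of methoxy on an aromatic carbon. Among the measured compounds shown here, no measured pair shows what this exchange does in this assay. The expectation is therefore a step no larger than the usual scatter, in neither direction. The estimated step is a number no higher from compound 3 to compound 4 (the limit leaves the size open), and a further limit is quite likely. For compound 4 the expected value is 100000 nM, with an estimated range from 30000 nM to 200000 nM.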

Compound 4, half-maximal inhibitory concentration: > 100000 nM
Compound 4 ended at the assay's limit; the forecaster's own chance of this, stated with the estimate: 65%; the middle value sits exactly at the limit.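

Compound 3 and compound 4 both stand at a limit in this assay, and no step can be read between them: the limit of > 100000 nM in this assay, at which 3 of the 4 values shown sit. The compounds shown leave open whether methyl in place of methoxy changes cytotoxicity on the shared core at all.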